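Replacing the methoxy group of compound 1 with hydrogen

The source may hold more compounds than are shown below. What is called first, only, known or untested is meant among the compounds shown, and "the series" means these compounds.

compound 1 `COc1ccc(CCCOC(=O)CCc2ccc(O)cc2)cc1`: 108000 nM
compound 2 `COc1ccc(/C=C/COC(=O)/C=C/c2cc(OC)c(OC)c(OC)c2)cc1OC`: 212000 nM

Both values come from a functional assay on BEL-7404 cells (Homo sapiens) for cytotoxicity, read by MTT assay, with a stated time of 72 h; a higher number here means a weaker inhibitor, a lower number a stronger inhibitor. Compound 1 stands at 108000 nM, and compound 2 lies within the scatter of it, so the two cannot be ranked. The next compound to be read is compound 3 `O=C(CCc1ccc(O)cc1)OCCCc1ccccc1`, which carries hydrogen in place of methoxy on an aromatic carbon. Among the compounds with values here, no measured pair shows this change, so the data give no direct guide to its size. Within the data shown here, the only anchor is compound 1 at 108000 nM. No step beyond the scatter is expected in this assay, and no firm direction can be given. The estimated shift is a 1.1-fold higher number from compound 1 to compound 3 (0.05 log units; within the scatter). For compound 3 the estimated value is 120000 nM, with an expected range from 50000 nM to 290000 nM.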

Compound 3, half-maximal inhibitory concentration: 217000 nM
Estimate against measurement, compound 3: 1.8-fold (0.26 log units) below, and the stated range covers the measured number.
By their numbers in this assay, from the lowest: compounds 1, 2 and 3 (each within the scatter of the next).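

Within the data shown here, this is the first measured pair for hydrogen in place of methoxy on an aromatic carbon, para to a large group. In this assay, the change gives a 2.0-fold higher number from compound 1 to compound 3 (0.30 log units; within the scatter), so at this position the data show no step beyond the scatter on removing the methoxy group, and compound 1 and compound 3 cannot be ranked. No measurement on hand bears on why the step has this size.

On these data alone, whether an amine, a chlorine atom or a longer alkoxy chain at this aromatic carbon would give a step beyond the scatter remains open. Also open, as far as these compounds go, is whether hydrogen in place of methoxy gives a similar step elsewhere, including on the core of compound 2.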